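This account rests on a few compounds, and the source may have more. Where it says the series, first, only, none or still open, it means among the compounds named here.

Compound 1 `CCN(CC)CN1C(=O)/C(=N\c2nc3ccc(C)cc3s2)c2ccccc21`: 27500 nM
Compound 2 `Cc1ccc2nc(/N=C3\C(=O)N(CN(c4ccccc4)c4ccccc4)c4cccc(Cl)c43)sc2c1`: 67800 nM
Compound 3 `CCN(CC)CN1C(=O)/C(=N\c2nc3ccc(C)cc3s2)c2c(Cl)cccc21`: 87800 nM

In an ADME assay on 184B5 cells (Homo sapiens) for cytotoxicity, read by sulforhodamine B assay, with a stated time of 48 h (a higher number here means a weaker inhibitor of growth, a lower number a stronger inhibitor of growth), compound 3 gives 87800 nM, while compound 1 gives 27500 nM. The two differ by one change, (hydrogen in place of chloro on an aromatic carbon), and that change made a 3.2-fold lower number from compound 3 to compound 1 (0.50 log units; beyond the scatter). Compound 2 gives 67800 nM in this assay; how its core differs from that of compound 3 is not broken down here, and their two values lie within the scatter of each other.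

Compound 4 `Cc1ccc2nc(/N=C3\C(=O)N(CN(c4ccccc4)c4ccccc4)c4ccccc43)sc2c1` has not yet been measured in this assay. It differs from compound 2 by hydrogen in place of chloro on an aromatic carbon, the same change as that from compound 3 to compound 1, made at a place described in identical words. Resting on a 3.2-fold lower number from compound 3 to compound 1 (0.50 log units; beyond the scatter), the expected step is a 3.1-fold lower number from compound 2 to compound 4 (0.49 log units; beyond the scatter). Compound 4 is therefore estimated at 22000 nM, most likely between 9000 nM and 55000 nM.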

Compound 4, concentration for 50% growth inhibition: 27200 nM
Compound 4: the middle estimate sits 1.2-fold (0.09 log units) below what was measured; measured number inside the range.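

Replacing chloro with hydrogen gave a 2.5-fold lower number from compound 2 to compound 4 (0.40 log units; beyond the scatter) in this assay. Set beside the earlier step, the change carried over from one core to the other in direction and, within the scatter, in size: the same change on two cores in this assay, a 3.2-fold lower number (0.50 log units; beyond the scatter) from compound 3 to compound 1 and a 2.5-fold lower number (0.40 log units; beyond the scatter) from compound 2 to compound 4, 1.3-fold (0.11 log units) apart, within the scatter of two such steps This agreement rests on only two cores and one place on the aromatic ring, so it does not show that the change would carry over to other cores in the series or to other assays, and it does not explain why the step occurs.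

Going by these compounds, only chloro and hydrogen appear at this place, so the effect of a fluoro, a methoxy or an amine there remains open. Also open, on these data alone, is whether the step would persist with a longer chain on the ring nitrogen of the core.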